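The source may report more compounds than this note shows. Statements on the series, on what has been measured and on what is new or still open speak of the compounds shown alone.

Of the compounds shown here, two have so far been measured in a physicochemical assay for acid dissociation. Compound 1 `COc1cccc(CNCCCNc2ccnc3cc(Oc4ccc(Cl)cc4)ccc23)c1O` gives 9.28 in this assay. Compound 2 `COc1ccc(F)cc1CNCCCNc1ccnc2cc(-c3ccc(F)cc3)ccc12` gives 9.47 in this assay. Of these two numbers, compound 1 holds the lower one, yet its nearest neighbour, compound 2, lies within the usual scatter of it, so the two cannot be told apart. Going by the values given here, compound 2 differs from compound 1 in more than one place, so no single structural step between measured compounds can be read off.

Compound 3 `COc1cccc(CNCCCNc2ccnc3cc(Oc4ccc(C(C)(C)C)cc4)ccc23)c1O` has not yet been measured in this assay. It differs from compound 1 in one place only: tert-butyl in place of chloro on an aromatic carbon. Among the compounds with values here, nothing among the measured pairs shows a step of this kind, so there is no anchor for its size. Neither the group that leaves nor the group that enters brings a hydrogen-bond donor, a hydrogen-bond acceptor or a charge, as the count shows. The step expected is a number 0.02 log units higher from compound 1 to compound 3 (within the scatter), that is, none beyond the scatter. For compound 3 the estimated value in this assay is 9.3, with a range from 9 to 9.6.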

Compound 3, acid dissociation constant: 9.28
The estimate for compound 3 lay 0.02 log units above the measured number, within the range that was stated.
By their numbers in this assay, from the lowest: compounds 1, 3 and 2 (each within the scatter of the next).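

Going by these compounds alone, only compounds 1 and 3 differ in a single place, so this pair gives the one clean comparison here: replacing 4-chlorophenoxy with 4-(tert-butyl)phenoxy produces no change at the digits printed from compound 1 to compound 3 (within the scatter) in this assay. At this position on a six-membered aromatic ring of carbon only, a single chlorine atom can therefore give way to a tert-butyl group of four carbon atoms without the read-out moving beyond the usual scatter. Nothing measured here accounts for this result.

The compounds shown leave open whether a different kind of group at the same place, such as an amine or a carboxylic acid, would also leave the number in this assay within the scatter of compound 1. They also leave open whether replacing chloro with tert-butyl would read the same way in another pair of compounds, since this single pair says nothing beyond compounds 1 and 3.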